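The compounds below may be only part of what the source reports. "The series", "measured", "known", "first", "only" and "open" are said of these compounds alone.

Compound 1 `NC(=O)c1cnc(Oc2ccc3c(c2)B(O)OC3)cn1`: 48200 nM
Compound 2 `CCOC(=O)c1cnc(Oc2ccc3c(c2)B(O)OC3)cn1`: 16800 nM

Among the compounds with values here, in an ADME assay on Jurkat cells (Homo sapiens) for cytotoxicity, read by MTT assay, with a stated time of 72 h (on this read-out lower numbers stand for stronger inhibition and higher numbers for weaker inhibition), compound 2 gives 16800 nM, the lower of the two numbers measured so far. The next structure is compound 3 `CC(C)(C)OC(=O)c1cnc(Oc2ccc3c(c2)B(O)OC3)cn1`, which has tert-butyl in place of ethyl on an oxygen next to a carbonyl group. Within the data shown here, only one measured step bears on this change: a 2.9-fold lower number from compound 1 to compound 2 (0.46 log units; beyond the scatter). That modest step, ethoxy in place of amino on a carbonyl carbon, went beyond the scatter, but it swapped a different kind of group, so it is only a loose guide. A single step also sets no trend. A small move towards a lower number is therefore expected, possibly one that stays within the scatter: a 1.3-fold lower number from compound 2 to compound 3 (0.11 log units; within the scatter). For compound 3 the estimated value is 13000 nM, with an expected range of 5500 nM to 30000 nM.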

Compound 3, half-maximal inhibitory concentration: > 100000 nM
Compound 3: no number, only a limit; the forecaster's own chance of this, stated with the estimate: 7%; middle value at least 7.6-fold (0.88 log units) away from the limit.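

In this assay, exchanging ethoxycarbonyl for tert-butoxycarbonyl reverses the direction of the earlier change, giving an at least 5.9-fold higher number from compound 2 to compound 3 (0.77 log units; beyond the scatter). Replacing amino on the carbonyl carbon with an alkoxy group therefore does not always lower the number: ethoxy lowered it, whereas tert-butoxy gives an at least 2.0-fold higher number from compound 1 to compound 3 (0.31 log units; beyond the scatter). Compound 3 stands at a limit, not at a measured number: the limit of > 100000 nM in this assay, at which 1 of the 3 values shown sits.

The true size of both new steps remains open, as the compounds shown do not tell how far the number of compound 3 lies past that limit. They also leave open how an isopropyl or n-propyl ester, or a carboxylic acid in the same place, would read, and so whether branching or chain length matters more here.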